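Cytotoxicity of a Fourth Amide Analogue, Anticipated Before Measurement

A few compounds are considered here, and "the series" means these few. Any claim that something is new, unique, unknown or untested is made for them only; others in the source may bear on it.

Of the compounds shown here, three have been tested so far, all built on the same core. Compound 1 `Cn1c(-c2ccc(C#N)cc2)cnc1NC(=O)c1ncc[nH]1` carries a nitrile-bearing aryl on the core and an imidazole-derived amide. In a toxicity assay on THP-1 cells (Homo sapiens) for inhibition (a higher number here means that more compound is tolerated, a lower number that less compound is tolerated), compound 1 gives > 100000 nM, which is a limit of the assay rather than a number. Compound 2 `Cn1c(-c2ccccc2F)cnc1NC(=O)c1ccc(F)cc1` pairs a fluorophenyl on the core with a fluorobenzamide. Compound 2 likewise reaches only the limit of > 100000 nM in this assay. Compound 3 `COc1ccc(-c2cnc(NC(=O)c3ccccc3F)n2C)cc1` bears a methoxyphenyl on the core and a 2-fluorophenyl amide. Compound 3 also stands at a limit in this assay, namely > 100000 nM. The whole picture so far is one line: the limit of > 100000 nM in this assay, at which 3 of the 3 values shown sit.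

Compound 4 `COc1ccc(-c2cnc(NC(=O)c3cccc(C#N)c3)n2C)cc1` differs from compound 3 in a single place: 3-cyanophenyl in place of 2-fluorophenyl on a carbonyl carbon. Within the data shown here, no step between measured compounds exists to guide the reader, and every measured value rests at the limit, (the limit of > 100000 nM in this assay, at which 3 of the 3 values shown sit), so the step from compound 3 to compound 4 is expected to be none beyond the scatter, meaning a number no higher from compound 3 to compound 4 (the limit leaves the size open). Compound 4 is therefore estimated at 100000 nM, within a range from 50000 nM to 200000 nM, and most likely it will again be reported only as a limit.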

Compound 4, half-maximal cytotoxic concentration: > 100000 nM
Compound 4: no number, only a limit; the forecaster's own chance of this, stated with the estimate: 85%; the middle value lies on the limit itself.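

Among these compounds, compound 3 and compound 4 both stand at limits of this assay, so no step between them can be read. The series remains at one line: the limit of > 100000 nM in this assay, at which 4 of the 4 values shown sit. The compounds shown leave open whether 3-cyanophenyl in place of 2-fluorophenyl changes the tolerated concentration at all, and where any of these compounds would reach its half-maximal cytotoxic concentration.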